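Ethoxy to carbamoyl on the benzyl arm

This account rests on a few compounds, and the source may have more. Where it says the series, first, only, none or still open, it means among the compounds named here.

Measured so far in a toxicity assay on MDCK cells (Canis lupus familiaris) for cytotoxicity, read by crystal violet staining, with a stated time of 48 h; a lower number here means that less compound is tolerated, a higher number that more compound is tolerated:
Compound 1 `Cc1ccc2[nH]c(=O)c(CN(Cc3ccc(F)cc3)Cc3ccc(C(C)(C)C)cc3)cc2c1` gives > 27000 nM, a limit of the assay.
Compound 2 `COCOc1ccc(CN(Cc2ccc(C(C)(C)C)cc2)Cc2cc3cc(C)ccc3[nH]c2=O)cc1` gives 6400 nM.
Compound 3 `CCOc1ccc(CN(Cc2ccc(C(C)(C)C)cc2)Cc2cc3cc(C)ccc3[nH]c2=O)cc1` gives > 10000 nM, a limit of the assay.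

Compound 3 therefore stands only at a limit in this assay; of the three, compound 2 alone returns a number. Compound 4 `Cc1ccc2[nH]c(=O)c(CN(Cc3ccc(C(N)=O)cc3)Cc3ccc(C(C)(C)C)cc3)cc2c1` differs from compound 3 by carbamoyl in place of ethoxy on an aromatic carbon. The steps measured on that same aromatic carbon are an at least 4.2-fold lower number from compound 1 to compound 2 (0.62 log units; beyond the scatter), an at least 1.5-fold higher number from compound 2 to compound 3 (0.19 log units; that floor lies within the scatter) and a step that the two limits leave unreadable from compound 1 to compound 3; none of them involves a carbamoyl, so they set no clear direction. Compound 3 sits at the limit of > 10000 nM in this assay, at which 1 of the 3 values shown sits, and compound 4 is expected to remain close to it, with no step beyond the scatter, a step that the limit leaves unreadable from compound 3 to compound 4. The estimate for compound 4 in this assay is 13000 nM, expected between 5000 nM and 30000 nM.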

Compound 4, half-maximal cytotoxic concentration: > 5000 nM
Compound 4 was reported as a limit (the forecaster's own chance of this, stated with the estimate: 60%); the middle value does not contradict the limit.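

Compound 4 gives > 5000 nM, a limit of the assay, and its steps to compound 1, compound 2 and compound 3 cannot be read. The compounds shown leave open what carbamoyl in place of ethoxy does in this assay.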